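Inverting the stereocentre of compound 3

The source may hold more compounds than are shown below. What is called first, only, known or untested is meant among the compounds shown, and "the series" means these compounds.

In a functional assay for inhibition, with Rattus norvegicus as the target (on this read-out lower numbers stand for stronger inhibition and higher numbers for weaker inhibition), compound 1 `C[C@@H](/N=c1\c(O)c(O)\c1=N/c1ccc(C#N)cc1)c1ccccc1` gives 56 nM. Compound 2 `C[C@H](/N=c1\c(O)c(O)\c1=N/c1ccc(C#N)cc1)c1ccccc1` gives > 30000 nM, which is a limit of the assay. Compound 3 `CC[C@@H](/N=c1\c(O)c(O)\c1=N/c1ccc(C#N)cc1)c1ccccc1` gives 22500 nM, the higher of the two actual numbers in the series. Methyl in place of hydrogen on the chain carbon produced a 400-fold higher number from compound 1 to compound 3 (2.60 log units; beyond the scatter). Compound 4 `CC[C@H](/N=c1\c(O)c(O)\c1=N/c1ccc(C#N)cc1)c1ccccc1` follows from compound 3 by the two compounds have the same atoms and bonds and differ only in configuration as drawn: 1 of 3 stereo elements differ; a stereocentre at a saturated chain carbon is drawn R in compound 3 and S in compound 4. The only measured inversion, an at least 530-fold higher number from compound 1 to compound 2 (2.72 log units; beyond the scatter), suggests a higher number in this assay. Compound 3 at 22500 nM leaves only a small measurable span, so a much smaller step is expected: a 1.3-fold higher number from compound 3 to compound 4 (0.12 log units; within the scatter). For compound 4 the estimated value is 30000 nM, with an expected range of 8000 nM to 60000 nM. A report as a limit alone is quite possible.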

Compound 4, half-maximal inhibitory concentration: > 30000 nM
Compound 4: only a limit was reported; the forecaster's own chance of this, stated with the estimate: 60%; the middle value sits exactly at the limit.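

In this assay compound 4 gives > 30000 nM, which is a limit of the assay. On the lengthened chain, inversion gives only a floor, an at least 1.3-fold higher number from compound 3 to compound 4 (0.12 log units; that floor lies within the scatter), so it cannot show whether the large effect of inversion seen in an at least 530-fold higher number from compound 1 to compound 2 (2.72 log units; beyond the scatter) recurs at this carbon. The step from compound 2 to compound 4 cannot be read, and the size of the inversion on this chain also stays unreadable because of the shared ceiling: the limit of > 30000 nM in this assay, at which 2 of the 4 values shown sit.

Open, as far as these compounds go, is whether a longer chain, or a chain ending in an amine or a carboxylic acid, would give a measurable number in either configuration at this carbon.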